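The source may report more compounds than this note shows. Statements on the series, on what has been measured and on what is new or still open speak of the compounds shown alone.

Measured compounds:
Compound 1 `C=C(F)C(=O)Nc1cc(Nc2nccc(-c3cn(C)c4ccccc34)n2)c(OC)cc1N(C)CCN(C)C` — in a functional assay on NCI-H1975 cells (Homo sapiens) for antiproliferative activity, read by MTT assay, with a stated time of 72 h (a higher number here means a weaker inhibitor, a lower number a stronger inhibitor), compound 1 gives 4230 nM.
Compound 2 `C=C(Cl)C(=O)Nc1cc(Nc2nccc(-c3cn(C)c4ccccc34)n2)c(OC)cc1N(C)CCN(C)C` — in this assay compound 2 gives 1290 nM.

Compound 2 carries the lowest of the two numbers in this assay, and its nearest neighbour is compound 1, separated by a 3.3-fold lower number from compound 1 to compound 2 (0.52 log units; beyond the scatter). The structural difference behind that step is small: chloro in place of fluoro on a double-bonded chain carbon bound to a carbonyl carbon.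

Compound 3 `COc1cc(N(C)CCN(C)C)c(NC(=O)C(Cl)=C(Cl)Cl)cc1Nc1nccc(-c2cn(C)c3ccccc23)n1` has not yet been tested in this assay. Compared with compound 2, the change is 1,2,2-trichloroethenyl in place of 1-chloroethenyl on a carbonyl carbon. Among the compounds with values here, only one measured step bears on it, the one from compound 1 to compound 2, which showed that swapping one halogen for another on this chain moved the number beyond the scatter. Adding two further chlorines is a larger change, and no measured pair shows what that does; the direction cannot be read from the step in hand. The step from compound 2 to compound 3 is therefore expected to be modest and uncertain in sign, estimated as a 1.9-fold higher number from compound 2 to compound 3 (0.29 log units; within the scatter). Compound 3 is expected to give about 2500 nM in this assay, within a range from 600 nM to 10000 nM.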

Compound 3, half-maximal inhibitory concentration: > 50000 nM
Compound 3 ended at the assay's limit (the forecaster's own chance of this, stated with the estimate: 5%); at least 20-fold (1.30 log units) between middle value and limit.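

In this assay compound 3 gives > 50000 nM, which is a limit of the assay and not a number: the limit of > 50000 nM in this assay, at which 1 of the 3 values shown sits.

Exchanging fluoro for chloro on the chain gave only a 3.3-fold lower number from compound 1 to compound 2 (0.52 log units; beyond the scatter), whereas placing 1,2,2-trichloroethenyl on the carbonyl carbon gives an at least 38-fold higher number from compound 2 to compound 3 (1.58 log units; beyond the scatter), and likewise an at least 11-fold higher number from compound 1 to compound 3 (1.07 log units; beyond the scatter). This position therefore responds far more strongly to the change in this group than the halogen swap alone could show, and the idea that more chlorine on the chain brings a lower number fails: compound 2 fits it, but compound 3 goes clearly against it.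

The compounds shown leave open how much of the change is needed to produce this loss, a question that an intermediate group such as 1,2-dichloroethenyl would help to answer. On these data alone, they also leave open how other groups on the same carbonyl carbon would behave, for example a bromoethenyl group or a plain ethenyl group with no halogen at all, and so the trend across the halogens remains unknown.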